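Compound 3 to compound 4: a bromo-fluoro aryl amide

This account rests on a few compounds, and the source may have more. Where it says the series, first, only, none or still open, it means among the compounds named here.

In an in vitro ADME assay on microsomes from liver (Homo sapiens) for pharmacokinetics, read by LC-MS, with a stated time of 10 min, tested at 1 uM (on this read-out higher numbers stand for fast clearance and lower numbers for slow clearance), compound 1 `CN1C[C@H](C(=O)Nc2ccccc2)[C@@H](c2ccc(/C=C/C(=O)Nc3ccccc3N)cc2)C1` gives 7 mL/min/kg, compound 2 `CN1C[C@H](C(=O)Nc2ccc(F)cc2)[C@@H](c2ccc(/C=C/C(=O)Nc3ccccc3N)cc2)C1` gives 5 mL/min/kg and compound 3 `Cc1cccc(NC(=O)[C@H]2CN(C)C[C@@H]2c2ccc(/C=C/C(=O)Nc3ccccc3N)cc2)c1` gives 14 mL/min/kg. Compound 3 stays within the scatter of compound 1, with a 2.0-fold higher number from compound 1 to compound 3 (0.30 log units; within the scatter), but a 2.8-fold higher number from compound 2 to compound 3 (0.45 log units; beyond the scatter) sets it apart from compound 2. Compound 4 `CN1C[C@H](C(=O)Nc2ccc(F)c(Br)c2)[C@@H](c2ccc(/C=C/C(=O)Nc3ccccc3N)cc2)C1` has 3-bromo-4-fluorophenyl in place of 3-methylphenyl on an amide-type nitrogen. Among the measured compounds shown here, two steps bear on this change: the fluoro step, a 1.4-fold lower number from compound 1 to compound 2 (0.15 log units; within the scatter), and the larger step between compound 2 and compound 3. For the measured compounds named here, no measured compound carries bromo, so that part of the change is untested. The expected step, a 1.8-fold lower number from compound 3 to compound 4 (0.24 log units; within the scatter), points to a lower number but not beyond the scatter. Compound 4 is estimated at 8 mL/min/kg (expected range 4 mL/min/kg to 16 mL/min/kg).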

Compound 4, clearance: 15 mL/min/kg
The estimate for compound 4 lay 1.9-fold (0.27 log units) below the measured number, and the stated range covers the measured number.
By their numbers in this assay, from the lowest: compounds 2, 1, 3 and 4 (each within the scatter of the next, the first and the last beyond it).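

In this assay bromo in place of hydrogen on the 4-fluorophenyl amide now has a measured effect, beyond the scatter (a 3.0-fold higher number from compound 2 to compound 4 (0.48 log units; beyond the scatter)). The 3-bromo-4-fluorophenyl group also stands apart from phenyl (a 2.1-fold higher number from compound 1 to compound 4 (0.33 log units; beyond the scatter)), yet it cannot be told from 3-methylphenyl (a 1.1-fold higher number from compound 3 to compound 4 (0.03 log units; within the scatter)). Nothing shown here accounts for these steps. From the compounds shown here alone, whether bromo behaves the same without the fluoro remains open. So does what an amine or a carboxylic acid on this phenyl ring would give.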